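Removing the methoxy group from compound 2

The source may hold more compounds than are shown below. What is called first, only, known or untested is meant among the compounds shown, and "the series" means these compounds.

Among the measured compounds shown here, the series so far holds three measured compounds sharing no single step between them. Compound 1 `c1ccc(-c2nc3sc(-c4ccccc4)cn3n2)cc1` carries an unsubstituted phenyl at each end of the shared core; in a functional assay on NCI-H226 cells (Homo sapiens) for inhibition, read by sulforhodamine B assay, with a stated time of 48 h, tested at 10 uM (a higher number here means more inhibition of growth at the concentration tested, a lower number less inhibition of growth), compound 1 gives 27%. Compound 2 `COc1ccc(-c2nc3sc(-c4ccc(Cl)cc4)cn3n2)cc1` adds a methoxy on one phenyl and a chloro on the other, and in this assay compound 2 gives 49.9%, the highest of the three numbers, with compound 1 the nearest and compound 3 the furthest, both beyond the scatter. Compound 3 `C/C(=N/O)c1ccc(NC(=O)Cn2nc(C(F)(F)F)nc2N)cc1` is built on a different core; in this assay compound 3 gives 12.9%.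

The step to be followed leads from compound 2 to compound 4 `Clc1ccc(-c2cn3nc(-c4ccccc4)nc3s2)cc1`, which keeps the chloro but not the methoxy. The change is hydrogen in place of methoxy on an aromatic carbon.

Compound 1, lacking both groups, sits well below compound 2, so some loss on leaving the methoxy is expected. The step of a number 11.9 percentage points lower from compound 2 to compound 4 (beyond the scatter) is estimated as a modest fall, likely near the edge of the scatter. For compound 4 in this assay the expected value is 38%, with a range from 15% to 60%.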

Compound 4, percent growth inhibition at one concentration: 32%
Compound 4: middle estimate off by 6 percentage points, on the high side, within the range that was stated.
By their numbers in this assay, from the lowest: compound 3; then compounds 1 and 4 (each within the scatter of the next); then compound 2.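

In this assay, among the compounds shown here, hydrogen in place of methoxy para to a large group gives a number 17.9 percentage points lower from compound 2 to compound 4 (beyond the scatter) and this is the only reading of the methoxy alone, with the chloro held constant. Chloro in place of hydrogen on an aromatic carbon gives a number 5 percentage points higher from compound 1 to compound 4 (within the scatter) and so, of the two single changes now readable, only the loss of the methoxy lies beyond the scatter. No measurement shown gives a reason for either step.

On these data alone, whether this position favours the methoxy itself or would accept other groups stays open: a hydroxyl, an ethoxy or an amine on the same carbon would separate these cases. Also open, as far as these compounds go, is whether the methoxy step keeps its size on the core of compound 1 with no chloro present.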